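Replacing a Nitrile by a Nitro Group on the Aryl Ether

A few compounds are considered here, and "the series" means these few. Any claim that something is new, unique, unknown or untested is made for them only; others in the source may bear on it.

The compounds share one core, a carbamate joined through an ether oxygen to a benzene ring that carries a single substituent, and are tested in an assay for inhibition of zeta-carotene desaturase, chloroplastic/chromoplastic (Capsicum annuum), using a Dixon plot, with a stated time of 8 h; a higher number here means a weaker inhibitor, a lower number a stronger inhibitor. Compound 2 `CCC(COc1cccc(C#N)c1)OC(=O)NCc1ccccc1` carries a nitrile on that ring. In this assay compound 2 gives > 100000 nM, which is a limit of the assay and not a number. Compound 1 `CCC(COc1cccc(Br)c1)OC(=O)NCc1ccccc1` carries a bromine in the same position. In this assay compound 1 gives > 100000 nM, again a limit rather than a number. The step that the two limits leave unreadable from compound 1 to compound 2 is therefore unreadable: both values sit at the limit of > 100000 nM in this assay, at which 2 of the 2 values shown sit, and cannot be told apart.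

Compound 3 `CCC(COc1cccc([N+](=O)[O-])c1)OC(=O)NCc1ccccc1` is the next variation, differing from compound 2 by nitro in place of cyano on an aromatic carbon. Among the compounds with values here, only one measured step exists, and it carries no readable size, so there is no basis for predicting a gain or a loss in this assay. Within the data shown here, because the only comparable values sit at the limit of > 100000 nM in this assay, at which 2 of the 2 values shown sit, the expected step is a number no higher from compound 2 to compound 3 (the limit leaves the size open), meaning no readable change. Compound 3 is therefore expected to give 100000 nM, estimated within a range from 30000 nM to 300000 nM, most likely reported again as a limit.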

Compound 3, half-maximal inhibitory concentration: > 100000 nM
Compound 3 ended at the assay's limit; the forecaster's own chance of this, stated with the estimate: 85%; the middle value sits exactly at the limit.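

No new step can be read among compound 1, compound 2 and compound 3, since each result is a limit and not a number: the limit of > 100000 nM in this assay, at which 3 of the 3 values shown sit.

The compounds shown leave open how strongly any of the three inhibits the enzyme, and whether bromine, nitrile and nitro differ from one another at all.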